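Hydroxyphenyl position scan on the bromoindole-imidazole series

The compounds below may be only part of what the source reports. "The series", "measured", "known", "first", "only" and "open" are said of these compounds alone.

Measured so far:
compound 1, `Cc1ccc(Cn2cncc2-c2cc3cc(Br)ccc3[nH]2)cc1`, 21600 nM
compound 2, `Oc1ccccc1Cn1cncc1-c1cc2cc(Br)ccc2[nH]1`, 6400 nM

Compound 2 stands lowest of the two numbers in an assay on isolated protein for inhibition of Indoleamine 2,3-dioxygenase 1 (Homo sapiens), with a stated time of 1 h; on this read-out lower numbers stand for stronger inhibition and higher numbers for weaker inhibition; its nearest neighbour is compound 1, a 3.4-fold lower number from compound 1 to compound 2 (0.53 log units; beyond the scatter). Compound 3, `Oc1cccc(Cn2cncc2-c2cc3cc(Br)ccc3[nH]2)c1`, is not yet measured. It differs from compound 2 as follows: 3-hydroxyphenyl in place of 2-hydroxyphenyl on a saturated chain carbon bound to an aromatic nitrogen.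

Among the compounds with values here, only one measured step exists, and it bears on a different change (hydroxyl for methyl, with a different attachment on the phenyl), so it is a loose guide at best. Within the data shown here, no measured pair isolates the move of the hydroxyl from one position of the phenyl to another. The shared core and the hydroxyl are retained, so compound 3 is expected to land near compound 2, with a step of a 1.3-fold higher number from compound 2 to compound 3 (0.10 log units; within the scatter), which is within the scatter. Compound 3 is estimated at 8000 nM, in the range 2500 nM to 25000 nM.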

Compound 3, half-maximal inhibitory concentration: 1600 nM
The estimate for compound 3 lay 5.0-fold (0.70 log units) above the measured number; the measured number lies below the stated range.
By their numbers in this assay, from the lowest: compound 3; then compound 2; then compound 1.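

In this assay, the hydroxyl's place on the phenyl matters and not only its presence: with the same atoms joined differently, 3-hydroxyphenyl in place of 2-hydroxyphenyl gives a 4.0-fold lower number from compound 2 to compound 3 (0.60 log units; beyond the scatter). Against 4-methylphenyl on the same saturated chain carbon, 3-hydroxyphenyl gives a 14-fold lower number from compound 1 to compound 3 (1.13 log units; beyond the scatter), so compound 3 holds the lowest number of the three, with both of its steps beyond the scatter. Nothing available accounts for this difference between the two hydroxyphenyl groups.

Still open, going by these compounds, is how 4-hydroxyphenyl compares with 3-hydroxyphenyl, which would complete the position scan. Also open, on these data alone, is whether 3-methoxyphenyl or 3-aminophenyl keeps the lower number, and how 3-methylphenyl compares, since the step from compound 1 changes both the group and its place on the phenyl.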